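A few compounds are considered here, and "the series" means these few. Any claim that something is new, unique, unknown or untested is made for them only; others in the source may bear on it.

Compound 2 `Cc1cc(/C=C/C#N)cc(C)c1Oc1cc(Nc2ccc(C#N)cc2)c(N)cc1C(=O)NN` gives 2.4 ug/mL in a physicochemical assay for solubility, read by HPLC, in phosphate buffer, with a stated time of 4 h, at pH 7.4 (on this read-out lower numbers stand for lower solubility and higher numbers for higher solubility), the highest of the three numbers measured; compound 1 `CCNC(=O)c1cc(N)c(Nc2ccc(C#N)cc2)cc1Oc1c(C)cc(/C=C/C#N)cc1C` gives 1.08 ug/mL and compound 3 `Cc1cc(/C=C/C#N)cc(C)c1Oc1cc(Nc2ccc(C#N)cc2)c(N)cc1C(=O)NCCCO` gives 1.01 ug/mL. The step to compound 4 `Cc1cc(/C=C/C#N)cc(C)c1Oc1cc(Nc2ccc(C#N)cc2)c(N)cc1C(N)=O` is hydrogen in place of amino on an amide-type nitrogen. Among the compounds with values here, no measured step removes this amino outright; the two that touch the same amide-type nitrogen are a 2.2-fold higher number from compound 1 to compound 2 (0.35 log units; beyond the scatter) and a 2.4-fold lower number from compound 2 to compound 3 (0.38 log units; beyond the scatter), each a modest move in this assay when the amino is exchanged for an alkyl group. Replacing it with hydrogen is expected to give at most a modest step, most likely downward, as a 1.6-fold lower number from compound 2 to compound 4 (0.20 log units; within the scatter). Compound 4 is therefore estimated at 1.5 ug/mL, with a range from 0.6 ug/mL to 4 ug/mL.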

Compound 4, solubility: 0.63 ug/mL
Compound 4: the middle estimate sits 2.4-fold (0.38 log units) above what was measured, within the range that was stated.
By their numbers in this assay, from the lowest: compounds 4, 3 and 1 (each within the scatter of the next); then compound 2.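

In this assay, hydrogen in place of amino on the amide-type nitrogen gives a step beyond the scatter (a 3.8-fold lower number from compound 2 to compound 4 (0.58 log units; beyond the scatter)). Hydrogen in place of ethyl (a 1.7-fold lower number from compound 1 to compound 4 (0.23 log units; within the scatter)) or of 3-hydroxypropyl (a 1.6-fold lower number from compound 3 to compound 4 (0.20 log units; within the scatter)) stays within the scatter, so among these four compounds only compound 2 stands apart. No measurement here bears on the cause of these steps.

On these data alone, whether this standing is particular to the amino remains open. A hydroxyl or methoxy on the same nitrogen, or a longer chain ending in an amine or a carboxylic acid, would test that.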